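Amide substituent changes at the cytotoxicity assay limit

The compounds below may be only part of what the source reports. "The series", "measured", "known", "first", "only" and "open" are said of these compounds alone.

Compound 1 `O=C(O)c1ccc(CCOc2c(F)ccc3nc(C(=O)NCC4CCCCC4)[nH]c(=O)c23)cc1` is the reference point of this small set. In an ADME assay on HEK293 cells (Homo sapiens) for cytotoxicity, read by resazurin assay, with a stated time of 72 h (on this read-out higher numbers stand for lower toxicity in this test and lower numbers for higher toxicity in this test), compound 1 gives > 20000 nM, which is a limit of the assay and not a number. Compound 2 `O=C(O)c1ccc(CCOc2c(F)ccc3nc(C(=O)NCc4cccc(C5CC5)c4)[nH]c(=O)c23)cc1` gives > 20000 nM, likewise a limit. Compound 3 `CCc1ccc(CNC(=O)c2nc3ccc(F)c(OCCc4ccc(C(=O)O)cc4)c3c(=O)[nH]2)cc1` gives > 20000 nM, also a limit. Compound 1 therefore stands at the limit of > 20000 nM in this assay, at which 3 of the 3 values shown sit, and the steps a step that the two limits leave unreadable from compound 1 to compound 2, a step that the two limits leave unreadable from compound 1 to compound 3 and a step that the two limits leave unreadable from compound 2 to compound 3 are of unreadable size. Compound 4 `CCc1cccc(NC(=O)c2nc3ccc(F)c(OCCc4ccc(C(=O)O)cc4)c3c(=O)[nH]2)c1` differs from compound 1 by 3-ethylphenyl in place of cyclohexylmethyl on an amide-type nitrogen. The measured steps bear on this change only in that 3-cyclopropylphenyl or 4-ethylphenyl in place of cyclohexyl on a saturated chain carbon bound to an amide-type nitrogen left the read-out at the limit; no step beyond the scatter is expected in this assay, and the step of a number no higher from compound 1 to compound 4 (the limit leaves the size open) is expected to be nil. Compound 4 is accordingly estimated at 20000 nM, between 10000 nM and 40000 nM, most likely again reported only as a limit.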

Compound 4, half-maximal cytotoxic concentration: > 20000 nM
Compound 4 gave a limit, no number; the forecaster's own chance of this, stated with the estimate: 85%; the middle value lies on the limit itself.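

In this assay compound 4 gives > 20000 nM, again a limit and not a number, so its steps to compound 1, compound 2 and compound 3 cannot be read. Whether these amide substituents differ at all on this read-out stays open: the limit of > 20000 nM in this assay, at which 4 of the 4 values shown sit.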